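This account rests on a few compounds, and the source may have more. Where it says the series, first, only, none or still open, it means among the compounds named here.

Compounds measured so far:

Compound 1, `Cc1cccc(-c2ccnc(C(=O)Nc3ccc(Oc4ccnc5[nH]ccc45)c(F)c3)c2)c1`, gives 860 nM in a functional assay on PC-3 cells (Homo sapiens) for cytotoxicity, read by MTT assay, with a stated time of 72 h; on this read-out lower numbers stand for stronger inhibition and higher numbers for weaker inhibition.
Compound 2, `Cc1ccc(-c2ccnc(C(=O)Nc3ccc(Oc4ccnc5[nH]ccc45)c(F)c3)c2)c(C)c1`, gives 4010 nM in this assay.
Compound 3, `CCc1ccc(-c2ccnc(C(=O)Nc3ccc(Oc4ccnc5[nH]ccc45)c(F)c3)c2)cc1`, gives 2960 nM in this assay.

All three share one core and differ only in the ring that hangs from it. Compound 3 stands second highest of the three numbers: its nearest neighbour is compound 2, separated by a gap within the scatter, a 1.4-fold lower number from compound 2 to compound 3 (0.13 log units; within the scatter), while compound 1 lies further off, a 3.4-fold higher number from compound 1 to compound 3 (0.54 log units; beyond the scatter).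

The step to the new compound 4, `O=C(Nc1ccc(Oc2ccnc3[nH]ccc23)c(F)c1)c1cc(-c2ccc(C(F)(F)F)cc2)ccn1`, is trifluoromethyl in place of ethyl on an aromatic carbon. Going by the values given here, no measured step swaps one group for another at this same position para to a large group, so nothing speaks directly to this exchange. What the three values do show is that the two compounds carrying a group para to a large group, compound 2 and compound 3, sit close together, and both sit above compound 1 by steps beyond the scatter. Compound 4 keeps a group at that same place, so the expectation is a number near compound 3, with no step beyond the scatter: a 1.2-fold higher number from compound 3 to compound 4 (0.07 log units; within the scatter) is the expected change. The estimate for compound 4 in this assay is 3500 nM, expected to fall between 1200 nM and 10000 nM.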

Compound 4, half-maximal inhibitory concentration: 4350 nM
For compound 4 the middle estimate is 1.2-fold (0.09 log units) below the measured one, within the range that was stated.
By their numbers in this assay, from the lowest: compound 1; then compounds 3, 2 and 4 (each within the scatter of the next).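

In this assay, going by these compounds alone, this is the first exchange of one group for another at this place, on an aromatic carbon para to a large group, and going from ethyl to trifluoromethyl produces no separation that can be read (a 1.5-fold higher number from compound 3 to compound 4 (0.17 log units; within the scatter)). The comparison with the 2,4-dimethylphenyl compound is also within the scatter (a 1.1-fold higher number from compound 2 to compound 4 (0.04 log units; within the scatter)), whereas the gap to the 3-methylphenyl compound is beyond it (a 5.1-fold higher number from compound 1 to compound 4 (0.70 log units; beyond the scatter)), so among these four compounds, compounds 2, 3 and 4 form one group of similar numbers and compound 1 stands apart with a lower number. No measurement at hand gives a reason for this picture.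

Within the data shown here, what happens with a quite different group at this place, such as an amine, a carboxylic acid or a longer chain, remains open, so the tolerance seen here rests on only two groups at this spot, ethyl and trifluoromethyl. Among these compounds, also open is whether trifluoromethyl on the ring carbon that holds the methyl in compound 1 would give a number close to the one for compound 1 (860 nM) or close to those of the other three.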